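Sulfonamide isothiocyanate series: macrophage cytotoxicity, tail variations

A few compounds are considered here, and "the series" means these few. Any claim that something is new, unique, unknown or untested is made for them only; others in the source may bear on it.

Measured so far in an ADME assay on cells (Peritoneal macrophage, Mus musculus) for cytotoxicity, read by CCK-8 assay, with a stated time of 24 h; on this read-out lower numbers stand for higher toxicity in this test and higher numbers for lower toxicity in this test:
Compound 1 `COc1ccc(S(=O)(=O)N(CC(N)=O)c2ccc(N(CC(N)=O)S(=O)(=O)c3ccc(SCCCN=C=S)cc3)c3ccccc23)cc1` gives > 10000 nM, which is a limit of the assay and not a number.
Compound 2 `COc1ccc(S(=O)(=O)N(CC(N)=O)c2ccc(N(CC(N)=O)S(=O)(=O)c3ccc(SCCCCCN=C=S)cc3)c3ccccc23)cc1` gives > 10000 nM, again a limit.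
Compound 3 `COc1ccc(S(=O)(=O)N(CC(N)=O)c2ccc(N(CC(N)=O)S(=O)(=O)c3ccc([S+]([O-])CCN=C=S)cc3)c3ccccc23)cc1` gives > 10000 nM, again a limit.

For the measured compounds named here, compound 2 therefore stands only at a limit in this assay, the same limit at which every value so far sits (the limit of > 10000 nM in this assay, at which 3 of the 3 values shown sit). The steps among the measured compounds are all unreadable: a step that the two limits leave unreadable from compound 1 to compound 2, a step that the two limits leave unreadable from compound 1 to compound 3 and a step that the two limits leave unreadable from compound 2 to compound 3 can be given no size.

Compound 4 `COc1ccc(S(=O)(=O)N(CC(N)=O)c2ccc(N(CC(N)=O)S(=O)(=O)c3ccc(S(=O)(=O)CCOCCN=C=S)cc3)c3ccccc23)cc1` differs from compound 2 by a group of 11 heavy atoms (5 carbon, 1 nitrogen, 3 oxygen, 2 sulfur; no ring) in place of a group of 9 heavy atoms (6 carbon, 1 nitrogen, 2 sulfur; no ring), on an aromatic carbon. Going by the values given here, the steps that bear on it, changing the same tail of the shared core, are those just named, and none of them gave a readable size. No step beyond the scatter is expected, and the value is expected to remain at the limit: the estimated step is a number no higher from compound 2 to compound 4 (the limit leaves the size open). Compound 4 is accordingly estimated at 10000 nM, with a range from 5000 nM to 30000 nM, most likely reported only as a limit.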

Compound 4, half-maximal cytotoxic concentration: > 10000 nM
Compound 4: no number, only a limit; the forecaster's own chance of this, stated with the estimate: 85%; the middle value lies on the limit itself.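

The steps from compound 1, compound 2 and compound 3 to compound 4 cannot be read, since all four compounds sit at the same limit: the limit of > 10000 nM in this assay, at which 4 of the 4 values shown sit.

As far as these compounds go, how far any of these tails lies from a measurable cytotoxic concentration in this assay stays open.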